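This account rests on a few compounds, and the source may have more. Where it says the series, first, only, none or still open, it means among the compounds named here.

In a functional assay on YAC-1 cells (Mus musculus) (a lower number here means a smaller maximal response, a higher number a larger maximal response), compound 1 `Nc1nc(O)c2c(n1)n(C1OC(CO)[C@@H](O)[C@H]1O)c(=O)n2Cc1ccc(Cl)c(Cl)c1` gives 15%. Within the data shown here, of the two numbers measured so far this is the lower one: compound 2 `C=CCn1c(=S)n(C2OC(COC(C)=O)[C@H]3OC(C)(C)O[C@@H]23)c2nc(N)nc(O)c21` reaches 30%, a value that lies above compound 1 by more than the usual scatter of repeated measurements. The two compounds differ in several places at once, so nothing beyond that ordering can be read from their pair.

Compound 3 `N#Cc1ccc(Cn2c(=O)n(C3OC(CO)[C@@H](O)[C@H]3O)c3nc(N)nc(O)c32)cc1` has not yet been measured in this assay. It departs from compound 1 in one place: 4-cyanophenyl in place of 3,4-dichlorophenyl on a saturated chain carbon bound to an aromatic nitrogen. Among the measured compounds shown here, no measured pair in this set shows what such an exchange does to the maximal response, so the expectation for compound 3 rests only on compound 1 and on the small size of the change. The step of a number 5 percentage points higher from compound 1 to compound 3 (within the scatter) is expected to be small, pointing slightly upward but not clearly beyond the scatter. On that basis compound 3 is estimated to give 20% in this assay, with a plausible range from 8% to 40%.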

Compound 3, largest response reached (reported as maximal response), in percent of the reference or control that the assay uses: 0%
Compound 3: middle estimate off by 20 percentage points, on the high side; measured number below the stated range.
By their numbers in this assay, from the lowest: compound 3; then compound 1; then compound 2.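

Among these compounds, the exchange of 3,4-dichlorobenzyl for 4-cyanobenzyl provides the first comparison in this set that changes only one place, and in this assay it gives a number 15 percentage points lower from compound 1 to compound 3 (beyond the scatter) on the shared core. The maximal response therefore depends on the aromatic group held on a saturated chain carbon bound to an aromatic nitrogen, even though the two groups have the same count of heavy atoms and each has one six-membered aromatic ring of carbon only. Nothing available here accounts for the lower number with the 4-cyanophenyl group.

Because the exchange removes two chlorine atoms and adds a nitrile in one step, the pair cannot say whether the lower response goes with the loss of the chlorines or with the arrival of the nitrile, and a plain benzyl or a 4-chlorobenzyl group at this place would be needed to separate the two. From the compounds shown here alone, compound 2 differs from both compounds in several places, so it adds nothing on this point, and how a methoxy or a carboxylic acid on the same ring would behave remains open.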